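Series notes: thiazolopyrimidine-amines at A2b

The compounds below may be only part of what the source reports. "The series", "measured", "known", "first", "only" and "open" are said of these compounds alone.

Measured compounds:
- compound 1 `Nc1nc(-c2ccccc2)nc2sc(-c3ccccc3)nc12`: > 30000 nM in a functional assay on CHO cells for antagonist activity at adenosine receptor A2b (Homo sapiens), read by cAMP accumulation, with a stated time of 10 min; on this read-out lower numbers stand for stronger inhibition and higher numbers for weaker inhibition
- compound 2 `Nc1nc(-c2cccc(CO)c2)nc2sc(-c3ccccc3)nc12`: > 30000 nM
- compound 3 `Nc1nc(-c2ccccc2)nc2sc(-c3ccco3)nc12`: > 30000 nM

In this assay compound 3 gives only a limit, > 30000 nM, and no number. Compound 1 likewise shows only a limit in this assay. Compound 2 also sits at a limit and not at a number. Within the data shown here, the whole set therefore rests at the limit of > 30000 nM in this assay, at which 3 of the 3 values shown sit, so no compound can be placed in order against another.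

Compound 4 `Nc1nc(-c2cccc(CO)c2)nc2sc(-c3ccco3)nc12` differs from compound 3 by hydroxymethyl in place of hydrogen on an aromatic carbon, sitting meta to a large group on that ring. Among the measured compounds shown here, two measured steps bear on this change. The same replacement was made on compound 1 to give compound 2, but a step that the two limits leave unreadable from compound 1 to compound 2, so its size is not readable. The switch of the other aryl group, a step that the two limits leave unreadable from compound 1 to compound 3, is equally unreadable. Nothing measured here points to a readable gain from adding hydroxymethyl, and nothing points to a loss either.

Compound 4 is therefore expected to remain at or near the assay limit, with a number no higher from compound 3 to compound 4 (the limit leaves the size open) as the estimated step from compound 3 to compound 4. The expected value for compound 4 is 30000 nM, within a range of 10000 nM to 100000 nM, most likely reported again as a limit.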

Compound 4, half-maximal inhibitory concentration: > 30000 nM
Compound 4 was reported as a limit; the forecaster's own chance of this, stated with the estimate: 80%; the middle value lies on the limit itself.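

Neither new step can be read, from compound 3 to compound 4 or from compound 2 to compound 4, and the four compounds cannot be ordered in this assay: the limit of > 30000 nM in this assay, at which 4 of the 4 values shown sit.

The compounds shown leave open whether hydroxymethyl in place of hydrogen, or furan-2-yl in place of phenyl, changes inhibition at all.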